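Series notes: replacing the benzyloxy group of compound 2

The compounds below may be only part of what the source reports. "The series", "measured", "known", "first", "only" and "open" are said of these compounds alone.

Among the measured compounds shown here, compound 2 `Oc1nc2nonc2nc1Nc1ccc(OCc2ccccc2)cc1` shows the lowest number of the two measured so far in an assay on mitochondria from L6 cells (Rattus norvegicus) for activation, with a stated time of 90 min (on this read-out higher numbers stand for an effect only at larger amounts of compound and lower numbers for an effect already at smaller amounts), giving 2400 nM. For the measured compounds named here, the nearest comparison is compound 1 `Oc1nc2nonc2nc1Nc1ccc(OCC(F)(F)F)cc1`, which in this assay gives 42300 nM; the only measured step, an 18-fold lower number from compound 1 to compound 2 (1.25 log units; beyond the scatter), separates the two. Compound 3 `Oc1nc2nonc2nc1Nc1ccc(S(F)(F)(F)(F)F)cc1` has not been measured. It differs from compound 2 as follows: a group of 6 heavy atoms (5 fluorine, 1 sulfur; no ring) in place of a group of 8 heavy atoms (7 carbon, 1 oxygen; one six-membered aromatic ring of carbon only), on an aromatic carbon. Going by the values given here, the one step in hand bears on this only loosely: it shows a large gain when a ring-bearing group replaces a fluorinated group on the aromatic carbon, and compound 3 moves the other way, losing the ring and taking up a group of fluorine and sulfur with no ring. A higher number than that of compound 2 is expected for compound 3, a step of a 6.3-fold higher number from compound 2 to compound 3 (0.80 log units; beyond the scatter) in this assay. The new group has no measured parallel, so the range is wide. Compound 3 is estimated at 15000 nM, between 3000 nM and 80000 nM.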

Compound 3, half-maximal effective concentration: 3900 nM
Compound 3: the middle estimate sits 3.8-fold (0.59 log units) above what was measured; the measured number falls inside the stated range.
By their numbers in this assay, from the lowest: compounds 2 and 3 (each within the scatter of the next); then compound 1.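

In this assay, the ring of the benzyloxy group turns out not to be required at this aromatic carbon: a 1.6-fold higher number from compound 2 to compound 3 (0.21 log units; within the scatter) leaves compound 2 and compound 3 indistinguishable, although the group entering compound 3 has no ring. The other new step, an 11-fold lower number from compound 1 to compound 3 (1.04 log units; beyond the scatter), compares two ring-free groups of 6 heavy atoms each and still shows a large difference, so the presence of a ring cannot by itself account for the earlier gain. Nothing available explains why these groups give these numbers.

Still open, as far as these compounds go, is whether an amine, a carboxylic acid or a longer alkyl chain on the oxygen at this carbon would match compound 2 and compound 3 or fall nearer compound 1. From the compounds shown here alone, whether these steps carry over to any other core also remains open.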